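Piperidin-1-yl for Dimethylamino, Tested on Two Cores

A few compounds are considered here, and "the series" means these few. Any claim that something is new, unique, unknown or untested is made for them only; others in the source may bear on it.

In a functional assay on the whole organism with Mus musculus as the target (on this read-out higher numbers stand for an effect only at larger amounts of compound and lower numbers for an effect already at smaller amounts), compound 1 `Cc1c(N)c(C)c2c(c1CN(C)C)OC(C)(C)C2` reports only a limit, > 50 mg/kg. Compound 2 `Cc1c(N)c(C)c2c(c1CN1CCCCC1)OC(C)(C)C2` also reaches only a limit in this assay, > 50 mg/kg. Their change, (piperidin-1-yl in place of dimethylamino on a saturated chain carbon bound to an aromatic carbon), gives a step that the two limits leave unreadable from compound 1 to compound 2 because both sit at the limit of > 50 mg/kg in this assay, at which 2 of the 3 values shown sit. For the measured compounds named here, compound 3 `Cc1c(C)c2c(c(C)c1N)CC(C)(CCN(C)C)O2` gives 19 mg/kg in this assay, the only number among the three. How its core differs from the core of compound 1 is not broken down here. Compound 4 `Cc1c(C)c2c(c(C)c1N)CC(C)(CCN1CCCCC1)O2` carries the same kind of change, (piperidin-1-yl in place of dimethylamino on a saturated chain carbon, two bonds along the chain from a saturated ring carbon), but the place differs: on a saturated chain carbon bound to an aromatic carbon before, two bonds along the chain from a saturated ring carbon now. The earlier step is unreadable, so the expectation rests on compound 3 alone. The step is expected to be a 1.1-fold higher number from compound 3 to compound 4 (0.02 log units; within the scatter). Compound 4 is estimated at 20 mg/kg, between 8 mg/kg and 50 mg/kg.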

Compound 4, dose for 50% inhibition: 18.4 mg/kg
The estimate for compound 4 lay 1.1-fold (0.04 log units) above the measured number; the range from low to high includes it.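

On the second core, piperidin-1-yl in place of dimethylamino gives a 1.0-fold lower number from compound 3 to compound 4 (0.01 log units; within the scatter) in this assay, so on this core the two groups cannot be told apart. The step on the core of compound 1 cannot be read, and the two cores cannot be compared for this change, because both of its compounds stand at a limit and not at a number: the limit of > 50 mg/kg in this assay, at which 2 of the 4 values shown sit. The change is therefore shown on one core only, and a single readable step does not show that it carries from one core to another.

The compounds shown leave open how morpholin-4-yl or pyrrolidin-1-yl in the same place would read in this assay. They also leave open what a longer chain between the saturated ring carbon and the amine would give.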